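Swapping the Chloro-Trifluoromethylphenyl Pattern in a Diaryl Urea

The source may report more compounds than this note shows. Statements on the series, on what has been measured and on what is new or still open speak of the compounds shown alone.

Measured so far in a functional assay on HT-29 cells (Homo sapiens) for inhibition, read by MTT assay, with a stated time of 120 h; on this read-out lower numbers stand for stronger inhibition and higher numbers for weaker inhibition:
Compound 1 `CNC(=O)/C(C)=C/c1ccc(NC(=O)Nc2ccc(Cl)c(C(F)(F)F)c2)cc1` gives > 50000 nM, a limit of the assay.
Compound 2 `CNC(=O)CCc1ccc(NC(=O)Nc2ccc(Cl)c(C(F)(F)F)c2)cc1` gives 20600 nM.
Compound 3 `CC(NC(=O)/C=C/Oc1ccc(NC(=O)Nc2cc(C(F)(F)F)ccc2Cl)cc1)c1ccccc1` gives > 50000 nM, a limit of the assay.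

Compound 3 therefore stands at a limit of this assay rather than at a number; (the limit of > 50000 nM in this assay, at which 2 of the 3 values shown sit). Going by the values given here, the only measured step, an at least 2.4-fold lower number from compound 1 to compound 2 (0.38 log units; beyond the scatter), concerns the side chain and does not touch the aryl group on the urea, so no measured step bears directly on the change to compound 4 `CC(NC(=O)/C=C/Oc1ccc(NC(=O)Nc2ccc(Cl)c(C(F)(F)F)c2)cc1)c1ccccc1`, which is 4-chloro-3-(trifluoromethyl)phenyl in place of 2-chloro-5-(trifluoromethyl)phenyl on an amide-type nitrogen. This gives compound 4 the aryl arrangement of compounds 1 and 2, whose values are one limit and one weak number. Compound 4 is expected to stay weak, with an estimated step of an at least 1.2-fold lower number from compound 3 to compound 4 (0.09 log units; that floor lies within the scatter). The estimate for compound 4 is 40000 nM, ranging from 12000 nM to 120000 nM.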

Compound 4, half-maximal inhibitory concentration: > 50000 nM
Compound 4 gave a limit, no number (the forecaster's own chance of this, stated with the estimate: 55%); middle value at least 1.2-fold (0.09 log units) from the limit.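

Compound 3 and compound 4 each give only a limit in this assay, so the step between them cannot be read: the limit of > 50000 nM in this assay, at which 3 of the 4 values shown sit.

The compounds shown leave open whether replacing 2-chloro-5-(trifluoromethyl)phenyl with 4-chloro-3-(trifluoromethyl)phenyl changes inhibition at all.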